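Swapping an Ether for a Carbon Chain in Rat Microsomes

This account rests on a few compounds, and the source may have more. Where it says the series, first, only, none or still open, it means among the compounds named here.

Measured so far in an ADME assay (liver) for pharmacokinetics, with Liver microsome (Rattus norvegicus) as the target, read by LC-MS, using microsomes, tested at 2 uM; on this read-out higher numbers stand for fast clearance and lower numbers for slow clearance:
Compound 1 `O=C(N[C@@H]1CCCC[C@H]1O)c1cnc(OC2CCCCC2)c(-c2ccc(Cl)cc2)c1` gives 0.662 mL/min/kg.
Compound 2 `O=C(N[C@H]1CCCC[C@H]1O)c1cnc(OCC2CC2)c(-c2ccc(Cl)cc2)c1` gives 0.111 mL/min/kg.

Of these two numbers, compound 1 shows the higher clearance, and compound 2 sits well below it, a gap wider than the usual scatter. Compound 3 `O=C(N[C@@H]1CCCC[C@H]1O)c1cnc(CCC2CC2)c(-c2ccc(Cl)cc2)c1` has not been measured yet. It differs from compound 1 in one place: 2-cyclopropylethyl in place of cyclohexyloxy on an aromatic carbon. Within the data shown here, no measured pair isolates this kind of change, so its direction is open; the step of a 1.3-fold lower number from compound 1 to compound 3 (0.12 log units; within the scatter) is expected to be modest, probably within the scatter of this assay. Compound 3 is therefore estimated at 0.5 mL/min/kg, with a range from 0.12 mL/min/kg to 2 mL/min/kg.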

Compound 3, clearance: 1.5 mL/min/kg
Beside the measured number, compound 3's estimate is 3.0-fold (0.48 log units) below it, and the stated range covers the measured number.
By their numbers in this assay, from the lowest: compound 2; then compound 1; then compound 3.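

Putting 2-cyclopropylethyl in place of cyclohexyloxy, on the aromatic carbon next to the ring nitrogen, gives a step in this assay of a 2.3-fold higher number from compound 1 to compound 3 (0.36 log units; beyond the scatter). This is the first single-place change shown at this position, and it points toward faster clearance. No available evidence explains the rise. As far as these compounds go, the swap alters the atom attached to the aromatic carbon and the ring at the same time, so the part each plays remains open. A cyclohexylmethyl group at this position would keep the six-membered ring while replacing the oxygen with carbon, separating the two.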